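Replacing the Trimethoxyphenyl Group of Compound 2

The compounds below may be only part of what the source reports. "The series", "measured", "known", "first", "only" and "open" are said of these compounds alone.

Values measured in a functional assay on MGC-803 cells (Homo sapiens) for inhibition, read by CCK-8 assay, with a stated time of 48 h (on this read-out higher numbers stand for weaker inhibition and lower numbers for stronger inhibition), are as follows
- compound 1 `CCN1CCN(C(=S)SCC(=O)N(Cc2ccc(OC)cc2)c2cc(OC)c(OC)c(OC)c2)CC1` gives 9890 nM
- compound 2 `COc1ccc(CN(C(=O)CSC(=S)N2CCN(C(=O)OC(C)(C)C)CC2)c2cc(OC)c(OC)c(OC)c2)cc1` gives 310 nM
- compound 3 `COc1ccc(CN(C(=O)CSC(=S)N2CCN(Cc3ccc(C(C)(C)C)cc3)CC2)c2cc(OC)c(OC)c(OC)c2)cc1` gives 5390 nM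

Compound 2 has the lowest number of the three and so the strongest inhibition. Compound 4 `COc1ccc(CN(C(=O)CSC(=S)N2CCN(C(=O)OC(C)(C)C)CC2)c2ccc(Br)cc2)cc1` has 4-bromophenyl in place of 3,4,5-trimethoxyphenyl on an amide-type nitrogen. Going by the values given here, all three measured compounds carry the group being replaced, so no measured step tests this change directly. The nearest evidence comes from changes on an amine nitrogen in a ring, which gave a 32-fold lower number from compound 1 to compound 2 (1.50 log units; beyond the scatter) and a 17-fold higher number from compound 2 to compound 3 (1.24 log units; beyond the scatter) as large steps. A sizeable step is therefore expected in this assay, probably towards a higher number, as compound 2 starts from 310 nM at the bottom of the range. The estimated step is a 4.8-fold higher number from compound 2 to compound 4 (0.68 log units; beyond the scatter) for this swap. For compound 4 the expected value is 1500 nM within an estimated range of 250 nM to 9000 nM in this assay.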

Compound 4, half-maximal inhibitory concentration: > 20000 nM
Compound 4 gave a limit, no number; the forecaster's own chance of this, stated with the estimate: 3%; middle value at least 13-fold (1.12 log units) from the limit.
By their numbers in this assay, from the lowest: compound 2; then compounds 3 and 1 (each within the scatter of the next). At a limit, above all of these: compound 4.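

This is the first change shown on the amide-type nitrogen, and 4-bromophenyl in place of 3,4,5-trimethoxyphenyl gives an at least 64-fold higher number from compound 2 to compound 4 (1.80 log units; beyond the scatter). Compound 4 reads only as a limit in this assay, not as a number: the limit of > 20000 nM in this assay, at which 1 of the 4 values shown sits. The group on this nitrogen, the same in compound 1, compound 2 and compound 3, can therefore decide on its own whether the strong inhibition of compound 2 survives.

The compounds shown leave open whether the loss follows from removing the methoxy groups or from adding bromine. A plain phenyl or a 4-methoxyphenyl on this nitrogen would help separate the two.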